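The source may report more compounds than this note shows. Statements on the series, on what has been measured and on what is new or still open speak of the compounds shown alone.

Measured compounds:
- compound 1 `N/N=C/c1cc2ccccc2[nH]c1=O` — in a functional assay, read by spectrophotometry, with a stated time of 1 h (a lower number here means a stronger inhibitor, a higher number a weaker inhibitor), compound 1 gives 365000 nM
- compound 2 `Cc1ccc2[nH]c(=O)c(/C=N/N)cc2c1` — in this assay compound 2 gives 790000 nM
- compound 3 `Cc1ccc2[nH]c(=O)c(/C=N/NC(=O)CS(N)(=O)=O)cc2c1` — in this assay compound 3 gives 5830000 nM

Compound 2 stands second highest of the three numbers in this assay: the step of a 2.2-fold higher number from compound 1 to compound 2 (0.34 log units; beyond the scatter) is modest, and the step of a 7.4-fold higher number from compound 2 to compound 3 (0.87 log units; beyond the scatter) is larger. Compound 4 `Cc1ccc2[nH]c(=O)c(/C=N/CCO)cc2c1` is not yet measured; its difference from compound 2 is 2-hydroxyethyl in place of amino on a double-bonded nitrogen.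

Going by the values given here, of the two measured steps, only the one to compound 3 bears on this change, since it too alters the nitrogen end of the chain, and it gave a 7.4-fold higher number from compound 2 to compound 3 (0.87 log units; beyond the scatter). The step to compound 4 is not the same kind of change, so that step is only a rough guide. Here the amino group leaves altogether and a 2-hydroxyethyl enters, so a higher number is expected, of a size between that of the step to compound 3 and no change beyond the scatter. In this assay compound 4 is therefore estimated at 2000000 nM, within 600000 nM to 6000000 nM, which means an expected step of a 2.5-fold higher number from compound 2 to compound 4 (0.40 log units; beyond the scatter).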

Compound 4, half-maximal inhibitory concentration: 4180000 nM
For compound 4 the middle estimate is 2.1-fold (0.32 log units) below the measured one; the measured number falls inside the stated range.
By their numbers in this assay, from the lowest: compound 1; then compound 2; then compounds 4 and 3 (each within the scatter of the next).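

The change to 2-hydroxyethyl on the double-bonded nitrogen gives a 5.3-fold higher number from compound 2 to compound 4 (0.72 log units; beyond the scatter) in this assay, so a higher number also follows when the amino group leaves altogether, and not only when it is kept and substituted. Alongside a 7.4-fold higher number from compound 2 to compound 3 (0.87 log units; beyond the scatter), both changes at this end of the chain move away from compound 2 towards weaker inhibition, and neither compound goes against this. The leaving amino and the entering 2-hydroxyethyl have the same hydrogen-bond donor and acceptor counts, and nothing at hand accounts for the rise in the number.

Going by these compounds, whether a plain ethyl, a longer chain ending in hydroxyl, or a chain ending in an amine or a carboxylic acid on this nitrogen would give a lower number stays open. Also open, on these data alone, is whether the hydroxyl of 2-hydroxyethyl contributes at all to the step.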